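The source may report more compounds than this note shows. Statements on the series, on what has been measured and on what is new or still open speak of the compounds shown alone.

Compound 1 `COc1ccc2[nH]c(-c3nc(-c4ccccc4)no3)cc2c1` sits at a limit in a functional assay on Jurkat cells (Homo sapiens) for antiproliferative activity, read by WST assay, with a stated time of 72 h; on this read-out lower numbers stand for stronger inhibition and higher numbers for weaker inhibition: compound 1 gives > 50000 nM, which is a limit of the assay and not a number. Compound 2 `Fc1ccc2[nH]c(-c3nc(-c4ccccc4)no3)cc2c1` differs from it by fluoro in place of methoxy on an aromatic carbon; in this assay compound 2 gives 33800 nM, so the step is an at least 1.4-fold lower number from compound 1 to compound 2 (0.17 log units; that floor lies within the scatter). Compound 3 `COc1ccc2[nH]c(-c3nc(-c4ccc(Cl)cc4)no3)cc2c1` has a different core, differing from compound 1 by chloro in place of hydrogen on an aromatic carbon. For compound 3, this assay again reports only a limit, > 50000 nM. That leaves a step that the two limits leave unreadable from compound 1 to compound 3. Compound 4 `Fc1ccc2[nH]c(-c3nc(-c4ccc(Cl)cc4)no3)cc2c1` is not yet measured; it differs from compound 3 by fluoro in place of methoxy on an aromatic carbon, the same change at the same place as from compound 1 to compound 2. Because the limit of > 50000 nM in this assay, at which 2 of the 3 values shown sit, holds two of the three values and that earlier step was small, the step is expected to be about an at least 1.2-fold lower number from compound 3 to compound 4 (0.09 log units; that floor lies within the scatter). Compound 4 is therefore estimated at 40000 nM in this assay.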

Compound 4, half-maximal inhibitory concentration: > 50000 nM
Compound 4: only a limit was reported (the forecaster's own chance of this, stated with the estimate: 55%); middle value at least 1.2-fold (0.09 log units) away from the limit.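

In this assay compound 4 gives > 50000 nM, which is a limit of the assay and not a number. The change of methoxy to fluoro therefore cannot be sized on the core of compound 3, and the steps that end or start at a limit cannot be read, because so many values sit at one ceiling: the limit of > 50000 nM in this assay, at which 3 of the 4 values shown sit. Among these compounds, the one readable step, chloro in place of hydrogen, is an at least 1.4-fold higher number from compound 2 to compound 4 (0.17 log units; that floor lies within the scatter), so no lower number appears on the core of compound 3, yet this does not show that the change fails to carry over.

Still open, on these data alone, is whether an amine or a carboxylic acid at the place of the fluoro would bring a number clearly under the limit. The same question holds for a longer chain there.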